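The source may hold more compounds than are shown below. What is called first, only, known or untested is meant among the compounds shown, and "the series" means these compounds.

Measured so far:
compound 1 `Cc1ccc(S(=O)(=O)N2CCN(C)CC2)cc1C#Cc1cc(Cl)ccc1OCC(=O)O` — 21 nM
compound 2 `C[S+]([O-])c1cccc(C#Cc2cc(Cl)ccc2OCC(=O)O)c1` — 3.2 nM

Both numbers come from an assay on CHO cells for displacement of a labelled ligand from prostaglandin D2 receptor 2 (Homo sapiens), read by scintillation counting; a lower number here means a stronger inhibitor, a higher number a weaker inhibitor. Compound 1 holds the higher of the two; compound 2 gives a number that lies well beyond the scatter below it. Within the data shown here, no pairs differing in one place have been measured, so no step size is known.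

Compound 3 `Cc1ccc(S(=O)(=O)CC(C)C)cc1C#Cc1cc(Cl)ccc1OCC(=O)O` is not yet measured. Its change from compound 1 is isobutyl in place of 4-methylpiperazin-1-yl on a sulfonyl sulfur. Among the measured compounds shown here, with no comparable step to lean on, the expected step of a 1.4-fold lower number from compound 1 to compound 3 (0.15 log units; within the scatter) is small and unlikely to pass beyond the scatter. Compound 3 is therefore estimated at 15 nM, within 4 nM to 60 nM.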

Compound 3, inhibition constant: 3 nM
The estimate for compound 3 lay 5.0-fold (0.70 log units) above the measured number; the measured number lies below the stated range.
By their numbers in this assay, from the lowest: compounds 3 and 2 (each within the scatter of the next); then compound 1.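

In this assay, among these compounds, isobutyl in place of 4-methylpiperazin-1-yl on a sulfonyl sulfur gives a 7.0-fold lower number from compound 1 to compound 3 (0.85 log units; beyond the scatter), the first measured step at this place. The six-membered non-aromatic ring with its 2 nitrogens is therefore not required here, and an all-carbon group without a ring gives the lower number. No measurement at hand accounts for this step.

Still open, going by these compounds, is whether the ring or the nitrogens drive the step, which piperidin-1-yl on the same sulfur could separate. A longer chain or a cyclohexyl group would show how far the carbon group can grow.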